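The source may report more compounds than this note shows. Statements on the series, on what has been measured and on what is new or still open speak of the compounds shown alone.

Of the compounds shown here, three have been measured in an assay on isolated protein for inhibition of Amine oxidase [flavin-containing] B (Homo sapiens); a lower number here means a stronger inhibitor, a higher number a weaker inhibitor: compound 1 `C#CCNC1CCc2c(SCc3ccc(C(F)(F)F)cc3)cccc21` gives 9680 nM; compound 2 `C#CCNC1CCc2c(SCc3ccc(OC)cc3)cccc21` gives 1900 nM; compound 3 `C#CCNC1CCc2c(SCc3cccc(C(F)(F)F)c3)cccc21` gives 4.7 nM.

From compound 1 to compound 2 the change is methoxy in place of trifluoromethyl on an aromatic carbon, and it made a 5.1-fold lower number from compound 1 to compound 2 (0.71 log units; beyond the scatter). Compound 3 has the same atoms as compound 1, joined differently; the difference between the two cores is not broken down here. Compound 4 `C#CCNC1CCc2c(SCc3cccc(OC)c3)cccc21` is not yet measured and differs from compound 3 by methoxy in place of trifluoromethyl on an aromatic carbon. This is the same kind of change as that from compound 1 to compound 2, but the place differs: in compound 4 the methoxy is meta to a large group, in compound 2 it is para to a large group. Compound 4 is expected to show an 8.5-fold higher number from compound 3 to compound 4 (0.93 log units; beyond the scatter) because compound 3 already gives 4.7 nM, leaving little room for a further fall. The estimate for compound 4 in this assay is 40 nM, between 4 nM and 400 nM.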

Compound 4, half-maximal inhibitory concentration: 3190 nM
Compound 4: the middle estimate sits 80-fold (1.90 log units) below what was measured, outside the stated range (above it).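

In this assay, methoxy in place of trifluoromethyl gave a 680-fold higher number from compound 3 to compound 4 (2.83 log units; beyond the scatter), so on the core of compound 3 this change costs a great deal. The same change does not carry over from one core to the other, and its direction even reverses: the same change on two cores in this assay, a 5.1-fold lower number (0.71 log units; beyond the scatter) from compound 1 to compound 2 and a 680-fold higher number (2.83 log units; beyond the scatter) from compound 3 to compound 4, 3500-fold (3.54 log units) apart, beyond the scatter of two such steps. This shows that the result on one core cannot be assumed on the other, but two pairs do not show why the cores differ or what the change would do on a further core.

Still open, as far as these compounds go, is whether another group in the same place, such as a nitrile or a chlorine, would stay close to compound 3 at 4.7 nM or fall away as compound 4 does.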